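Removing the fluoro from compound 3: what to expect

A few compounds are considered here, and "the series" means these few. Any claim that something is new, unique, unknown or untested is made for them only; others in the source may bear on it.

The study tracks how long compounds survive in an ADME assay on a cell-free system (plasma, Mus musculus) for metabolic stability, read by LC-MS, tested at 2 uM; a lower number here means that the compound disappears faster, a higher number that the compound lasts longer. For the measured compounds named here, compound 1 `CCN1CCC(c2ccc3c(c2)oc(=O)n3C(=O)NCCCCc2ccccc2)CC1` gives 0.833 h, and compound 2 `CC(C)N1CCC(c2ccc3c(c2)oc(=O)n3C(=O)NCCCCc2ccccc2)CC1` gives 0.667 h; the one measured step, a 1.2-fold lower number from compound 1 to compound 2 (0.10 log units; within the scatter), lies within the scatter. Compound 3 `CN1CCC(c2cc3oc(=O)n(C(=O)NCCCCc4ccccc4)c3cc2F)CC1` gives 0.333 h and stands lowest of the three numbers, within the scatter of compound 2 but beyond it relative to compound 1.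

Compound 4 `CN1CCC(c2ccc3c(c2)oc(=O)n3C(=O)NCCCCc2ccccc2)CC1` differs from compound 3 in one place: hydrogen in place of fluoro on an aromatic carbon. Going by the values given here, no measured step bears directly on this change, since the only measured step concerns a methyl on a saturated chain carbon, not a fluoro on an aromatic carbon. Compound 4 shares its unfluorinated core with compounds 1 and 2, whose values in this assay sit above that of compound 3, so a modest rise is expected, though it may well stay within the scatter. The expected step is a 1.5-fold higher number from compound 3 to compound 4 (0.18 log units; within the scatter). Compound 4 is estimated at 0.5 h, with a range from 0.25 h to 1 h.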

Compound 4, half-life: 0.833 h
Beside the measured number, compound 4's estimate is 1.7-fold (0.22 log units) below it, and the stated range covers the measured number.
By their numbers in this assay, from the lowest: compounds 3, 2, 1 and 4 (each within the scatter of the next, the first and the last beyond it).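

In this assay, for the compounds shown here, the step at this aromatic carbon, ortho to the 1-methylpiperidin-4-yl group, is a 2.5-fold higher number from compound 3 to compound 4 (0.40 log units; beyond the scatter), so hydrogen in place of fluoro here moves the number beyond the scatter, which the one earlier step, made at the amine nitrogen, did not. Changes at that nitrogen stay small in the new steps, with a 1.2-fold higher number from compound 2 to compound 4 (0.10 log units; within the scatter) and no change at the digits printed from compound 1 to compound 4 (within the scatter), so methyl, ethyl and isopropyl cannot be told apart in the unfluorinated series. No measurement at hand bears on why the fluoro compound has the shorter half-life.

Going by these compounds, the fluoro appears here only with methyl on the amine nitrogen, so it remains open whether the step holds with ethyl or isopropyl there. The compounds shown also leave open how a chloro or a methoxy on this aromatic carbon would compare.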